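Compound 2 to compound 4: amino for 2-methoxyethoxy

A few compounds are considered here, and "the series" means these few. Any claim that something is new, unique, unknown or untested is made for them only; others in the source may bear on it.

In a functional assay on P388 cells (Mus musculus) for inhibition (on this read-out lower numbers stand for stronger inhibition and higher numbers for weaker inhibition), compound 1 `COCCOc1cc(/C=C/c2ccc3ccccc3c2)ccc1OC` gives 2990 nM and compound 2 `COCCOc1cc(/C=C\c2ccc3ccccc3c2)ccc1OC` gives 2990 nM, so compound 2 stands level with compound 1. These two share the same atoms and bonds and differ only in the double bond as drawn, and the step reads no change at the digits printed from compound 1 to compound 2 (within the scatter). Compound 3 `FC(F)(F)Oc1ccc(/C=C/c2ccc3ccccc3c2)cc1` reports only a limit, > 5000 nM.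

The next compound is compound 4 `COc1ccc(/C=C\c2ccc3ccccc3c2)cc1N`, which keeps the double bond drawing of compound 2. The change is amino in place of 2-methoxyethoxy on an aromatic carbon. Within the data shown here, the one measured step concerns configuration alone and gives no size for exchanging this substituent, so the expectation stands on thin ground. A modest move toward stronger inhibition is expected in this assay, though no change beyond the scatter remains quite possible. The expected step is a 3.0-fold lower number from compound 2 to compound 4 (0.48 log units; beyond the scatter). Compound 4 is estimated at 1000 nM, with an expected range of 100 nM to 5000 nM.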

Compound 4, half-maximal inhibitory concentration: 1820 nM
Compound 4: middle estimate off by 1.8-fold (0.26 log units), on the low side, and the stated range covers the measured number.
By their numbers in this assay, from the lowest: compounds 4, 1 and 2 (each within the scatter of the next). At a limit, above all of these: compound 3.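

In this assay, amino in place of 2-methoxyethoxy on this aromatic carbon gives a 1.6-fold lower number from compound 2 to compound 4 (0.22 log units; within the scatter). This position, ortho to a methoxy group, therefore holds a chain of 5 heavy atoms and a single nitrogen at levels that cannot be told apart, and the hydrogen-bond donor that enters with amino brings no change beyond the scatter. The earlier step could not speak to this position or to any substituent exchange, because of one fact: the fact that compounds 1 and 2 differ only in the configuration as drawn.

Open, as far as these compounds go, is whether a hydroxyl, an acetamide or a carboxylic acid on this carbon stays at the same level in this assay. Also open, from the compounds shown here alone, is whether amino keeps this level with the double bond as drawn in compound 1.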